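A few compounds are considered here, and "the series" means these few. Any claim that something is new, unique, unknown or untested is made for them only; others in the source may bear on it.

In a functional assay on SEM cells (Homo sapiens) for cytotoxicity, with a stated time of 72 h (on this read-out higher numbers stand for an effect only at larger amounts of compound and lower numbers for an effect already at smaller amounts), compound 1 (`C=C[C@@](C)(/C=C/c1ccc(O)c(/C=C(\C)C(=O)OCC)c1)CCC=C(C)C`) gives only a limit, > 36600 nM. Compound 2 (`CCOC(=O)/C(C)=C/c1cc(/C=C/[C@](C)(/C=C/c2ccc(OC)cc2)CCC=C(C)C)ccc1O`) also gives only a limit, > 36600 nM, so its position is bounded on one side and no number is known. Both compounds therefore rest at the same point: the limit of > 36600 nM in this assay, at which 2 of the 2 values shown sit. Compound 3 (`COc1ccc(/C=C/[C@@](C)(/C=C/c2ccc(O)c(/C=C/C(=O)c3ccccc3)c2)CCC=C(C)C)cc1`) carries 2-benzoylethenyl in place of 2-(ethoxycarbonyl)prop-1-en-1-yl on an aromatic carbon, ortho to a hydroxy group: 2-benzoylethenyl in place of 2-(ethoxycarbonyl)prop-1-en-1-yl on an aromatic carbon. For the measured compounds named here, the only measured step, a step that the two limits leave unreadable from compound 1 to compound 2, concerns another place on the molecule, and its size gives no guide to this exchange. A cautious expectation is therefore a modest move toward lower numbers, with a real chance that the result is again only a limit. The expected change is an at least 2.4-fold lower number from compound 2 to compound 3 (0.38 log units; beyond the scatter). The estimated value for compound 3 is 15000 nM, with an expected range of 3000 nM to 50000 nM.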

Compound 3, half-maximal effective concentration: 36600 nM
Compound 3: middle estimate off by 2.4-fold (0.39 log units), on the low side; low and high end bracket the measured number.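

In this assay compound 3 gives 36600 nM, a number and not a limit, and this is the first readable value among these compounds. Compound 2 gives > 36600 nM, which is a limit. The exchange of groups at this aromatic carbon, ortho to a hydroxy group, gives a number no higher from compound 2 to compound 3 (the limit leaves the size open). The size of the step therefore cannot be read, and the number for compound 3 stands at the same figure as the other two values: the limit of > 36600 nM in this assay, at which 2 of the 3 values shown sit.

The compounds shown leave open how a carboxylic acid or an amine at this aromatic carbon would read in this assay. They also leave open whether a longer chain between the aromatic ring and the carbonyl of the 2-benzoylethenyl group would bring the number lower.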